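The compounds below may be only part of what the source reports. "The series", "measured", "known", "first", "only" and "open" are said of these compounds alone.

Measured compounds:
compound 1 `COc1ccc([C@@H]2CC(=O)c3c(O)cc(OC)cc3O2)cc1`, >= 11300 nM
compound 2 `COc1ccc([C@@H]2C/C(=N\N)c3c(O)cc(OC)cc3O2)cc1`, >= 11300 nM

The read-out throughout is a functional assay on L5178Y cells (Mus musculus) for inhibition, read by MTT assay, with a stated time of 24 h; a higher number here means a weaker inhibitor, a lower number a stronger inhibitor. Compound 1 is the starting point, and its value, >= 11300 nM, is a limit of the assay rather than a number. Compound 2 likewise stops at a limit, >= 11300 nM. Both known values therefore sit at the same limit (the limit of >= 11300 nM in this assay, at which 2 of the 2 values shown sit), so compound 1 cannot be ranked against anything else on the numbers shown, and no step between measured compounds exists.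

Compound 3 `COc1cc(O)c2c(c1)O[C@H](c1ccc(OCC(O)CN3CCCCC3)cc1)CC2=O` has not yet been measured in this assay. It differs from compound 1 in a single place: 1-hydroxy-2-(piperidin-1-yl)ethyl in place of hydrogen on a saturated chain carbon bound to an oxygen on an aromatic ring. For the measured compounds named here, there is no measured step to lean on, so the direction of the change is open. My expectation is that the step of an at least 1.4-fold lower number from compound 1 to compound 3 (0.14 log units; that floor lies within the scatter) is a modest move toward stronger inhibition, while the chance that compound 3 also reports only a limit remains considerable. Compound 3 is estimated at 8000 nM, with a range from 2000 nM to 30000 nM.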

Compound 3, half-maximal inhibitory concentration: 9300 nM
For compound 3 the middle estimate is 1.2-fold (0.07 log units) below the measured one; low and high end bracket the measured number.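

In this assay, compound 3 is the only one of the compounds shown to give an actual number, 9300 nM, so placing 1-hydroxy-2-(piperidin-1-yl)ethyl on this saturated chain carbon bound to an oxygen on an aromatic ring gives a reading that is not a limit. Compound 1 gives >= 11300 nM, which is a limit of the assay and not a number. As far as these compounds go, the change therefore reads as an at least 1.2-fold lower number from compound 1 to compound 3 (0.08 log units; that floor lies within the scatter), and its true size stays unknown because the starting point is only a limit: the limit of >= 11300 nM in this assay, at which 2 of the 3 values shown sit.

From the compounds shown here alone, it remains open whether the piperidine ring itself matters, which a morpholine ring or a simple dimethylamine at the end of the same chain would help to show. Going by these compounds, it is equally open whether the hydroxy group on the chain matters, which could be tested by comparison with a plain propyl chain that carries the same piperidine ring.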